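The source may hold more compounds than are shown below. What is called first, only, known or untested is meant among the compounds shown, and "the series" means these compounds.

Measured compounds:
Compound 1, `CCn1ncc2c(Nc3ccc(OC(F)(F)F)cc3)ncnc21` — in an ADME assay on BaF3 cells (Mus musculus) for cytotoxicity (a lower number here means that less compound is needed, a higher number that more compound is needed for the effect), compound 1 gives > 10000 nM, a limit of the assay.
Compound 2, `NC(=O)c1cccc(Nc2cc(Nc3ccc(OC(F)(F)F)cc3)ncn2)c1` — in this assay compound 2 gives > 10000 nM, again a limit.
Compound 3, `CCn1cc2c(Nc3ccc(OC(F)(F)F)cc3)ncnc2n1` — in this assay compound 3 gives > 10000 nM, also a limit.

Compound 1 thus stands at the limit of this assay, not at a number, and this is the common position of all values shown: the limit of > 10000 nM in this assay, at which 3 of the 3 values shown sit. Compound 4, `FC(F)(F)Oc1ccc(Nc2ncnc3c2cnn3Cc2ccccc2)cc1`, differs from compound 1 by one change, (phenyl in place of methyl on a saturated chain carbon bound to an aromatic nitrogen), that is, phenyl in place of methyl on a saturated chain carbon bound to an aromatic nitrogen. For the measured compounds named here, no step between measured compounds is available to set a scale for this change. Compound 4 is expected to remain at or near the limit, with an expected step of a number no higher from compound 1 to compound 4 (the limit leaves the size open) of little or no size beyond the scatter. The estimate for compound 4 is 10000 nM, ranging from 3000 nM to 30000 nM.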

Compound 4, half-maximal effective concentration: > 10000 nM
Compound 4 was reported as a limit; the forecaster's own chance of this, stated with the estimate: 65%; the middle value sits exactly at the limit.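

In this assay compound 4 gives > 10000 nM, a limit. For the compounds shown here, compound 1 also stands at a limit, so no step between compound 1 and compound 4 can be read. The compounds shown leave open what actual number any of them would give in this assay, and whether any change to the structure moves the value: the limit of > 10000 nM in this assay, at which 4 of the 4 values shown sit.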